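The compounds below may be only part of what the source reports. "The series", "measured", "known", "first", "only" and "open" are said of these compounds alone.

Working notes on the series.

Compound 3 `CN(C)C(=O)C[C@@H]1CN[C@H](C(=O)N2CCC[C@H]2C#N)C1` gives 66% in an assay on the whole organism (plasma, strain Sprague-Dawley) for inhibition of Dipeptidyl peptidase 4 (Rattus norvegicus), with a stated time of 6 h, at a dose of 1 mg/kg by the oral route; a lower number here means less inhibition, a higher number more inhibition at the dose given (going by the name of the read-out). Among the three numbers so far it stands second highest. Compound 1 `N#C[C@@H]1CCCN1C(=O)[C@@H]1C[C@H](C(=O)N2CCOCC2)CN1` gives 73% in this assay, and the two values lie within the scatter of each other. Compound 2 `C=CC[C@@H]1CN[C@H](C(=O)N2CCC[C@H]2C#N)C1` gives 38% in this assay; the step of a number 28 percentage points higher from compound 2 to compound 3 (beyond the scatter) is beyond the scatter and modest, and it came with dimethylcarbamoyl in place of vinyl on a saturated chain carbon bound to a saturated ring carbon.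

The next compound, compound 4 `CCCNC(=O)[C@@H]1CN[C@H](C(=O)N2CCC[C@H]2C#N)C1`, has the same atoms as compound 3 joined differently: propylcarbamoyl in place of (dimethylcarbamoyl)methyl on a saturated ring carbon. Going by the values given here, the only measured step at this part of the core is the one from compound 2 to compound 3, which shows that a carbamoyl-bearing group on that ring carbon goes with higher inhibition than vinyl. Among the compounds with values here, no measured step tells what a rearrangement of such a group into propylcarbamoyl does, so no step beyond the scatter is expected in this assay; the expected step is a number 4 percentage points lower from compound 3 to compound 4 (within the scatter). For compound 4 the estimated value is 62%, with a range from 44% to 78%.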

Compound 4, a percentage reported as inhibition, in the whole organism at one dose (the size of the read-out at that dose, not a potency): 59%
Estimate against measurement, compound 4: 3 percentage points above; measured number inside the range.
By their numbers in this assay, from the lowest: compound 2; then compounds 4, 3 and 1 (each within the scatter of the next, the first and the last beyond it).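

Working notes, continued. In this assay, rearranging the same atoms into propylcarbamoyl on this saturated ring carbon, which adds the amide hydrogen, gives a number 7 percentage points lower from compound 3 to compound 4 (within the scatter) and so separates the two groups by no reliable margin. The carbamoyl group bound directly to the ring carbon also stands clear of allyl, with a number 21 percentage points higher from compound 2 to compound 4 (beyond the scatter) showing that the rise over compound 2 does not depend on the (dimethylcarbamoyl)methyl arrangement. The group on the carbonyl carbon does count, as a number 14 percentage points lower from compound 1 to compound 4 (beyond the scatter) comes with propylamino in place of morpholin-4-yl.

Nothing at hand explains any of these steps. Open, on these data alone, is where a carboxylic acid or a primary amine on this ring carbon, or a longer chain on the amide nitrogen, would fall in this assay relative to compound 1 and compound 2.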